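This account rests on a few compounds, and the source may have more. Where it says the series, first, only, none or still open, it means among the compounds named here.

Measured in a functional assay on MCF7 cells (Homo sapiens) for antiproliferative activity, read by MTT assay, with a stated time of 48 h; on this read-out higher numbers stand for weaker inhibition and lower numbers for stronger inhibition:
- compound 1 `CC(C)=CCC[C@]1(C)/C=C/[C@@H](OC(=O)C=C(C)C)[C@](C)(O)/C=C/C(=O)/C(C(=O)O)=C\C1`: 16100 nM
- compound 2 `CO/N=C/C1=C/C[C@](C)(CCC=C(C)C)/C=C/[C@@H](OC(=O)C=C(C)C)[C@](C)(O)/C=C/C1=O`: 2510 nM

Of these two, compound 2 has the lower number and is therefore the stronger inhibitor. Compound 3 `CC(C)=CCC[C@]1(C)/C=C/[C@@H](OC(=O)C=C(C)C)[C@](C)(O)/C=C/C(=O)/C(C(=O)N(C)C)=C\C1` has not yet been measured. The change leading to it is a group of 5 heavy atoms (3 carbon, 1 nitrogen, 1 oxygen; no ring) in place of a group of 4 heavy atoms (2 carbon, 1 nitrogen, 1 oxygen; no ring), on a double-bonded ring carbon: a dimethylcarbamoyl group enters on the double-bonded ring carbon. Within the data shown here, only one measured step touches this place, a 6.4-fold lower number from compound 1 to compound 2 (0.81 log units; beyond the scatter), a modest change beyond the scatter. Dimethylcarbamoyl matches neither earlier group. That single step is only a loose guide. It shows that this place can alter the number, but not how this new group will behave. The expected change is a 1.8-fold higher number from compound 2 to compound 3 (0.25 log units; within the scatter), a slight rise that stays within the scatter. For compound 3 the estimated value is 4500 nM, with an expected range of 1500 nM to 14000 nM.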

Compound 3, half-maximal inhibitory concentration: 3670 nM
Compound 3: the middle estimate sits 1.2-fold (0.09 log units) above what was measured; low and high end bracket the measured number.
By their numbers in this assay, from the lowest: compounds 2 and 3 (each within the scatter of the next); then compound 1.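

Putting dimethylamino in place of hydroxy on the carbonyl carbon gives a clear step in this assay (a 4.4-fold lower number from compound 1 to compound 3 (0.64 log units; beyond the scatter)), and this step lies beyond the scatter. Compound 3 thus gives a second case, after compound 2, in which a group without the hydroxy of compound 1 has a lower number at this double-bonded ring carbon. The dimethylcarbamoyl group and the group it replaces cannot be told apart on this read-out (a 1.5-fold higher number from compound 2 to compound 3 (0.16 log units; within the scatter)), as that step stays within the scatter, and nothing available explains either step.

The compounds shown leave open whether a methyl ester, an unsubstituted amide or a morpholine amide at this place would fall in the same range. They also leave open whether a longer chain on the amide nitrogen would do so.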